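The compounds below may be only part of what the source reports. "The series", "measured", "known", "first", "only" and "open" are said of these compounds alone.

Compound 1 `C[C@H]1CC[C@@H]2[C@@H](OC(=O)[C@]23CC(c2ccc(Cl)cc2)N(c2ccccc2)O3)[C@]2(C)C(=O)C=C[C@@]12O` and compound 2 `C[C@H]1CC[C@@H]2[C@@H](OC(=O)[C@]23CC(c2cccc(Cl)c2)N(c2ccccc2)O3)[C@]2(C)C(=O)C=C[C@@]12O` form the measured pair. In a physicochemical assay for lipophilicity (on this read-out higher numbers stand for higher lipophilicity and lower numbers for lower lipophilicity), compound 1 gives 3.87; in this assay compound 2 gives 3.87. The step of no change at the digits printed from compound 1 to compound 2 (within the scatter) is flat, so compound 2 stands level with compound 1. Compound 3 `C[C@H]1CC[C@@H]2[C@@H](OC(=O)[C@]23CC(c2ccc([N+](=O)[O-])cc2)N(c2ccccc2)O3)[C@]2(C)C(=O)C=C[C@@]12O` is not yet measured; the change is 4-nitrophenyl in place of 3-chlorophenyl on a saturated ring carbon. Among the compounds with values here, the only measured step, 3-chlorophenyl in place of 4-chlorophenyl, does not cover an exchange of 3-chlorophenyl for 4-nitrophenyl, so it offers no direct guide. A downward step beyond the scatter is expected: a number 0.97 log units lower from compound 2 to compound 3 (beyond the scatter). Compound 3 is estimated at 2.9, within 2.5 to 3.4.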

Compound 3, partition coefficient: 3.15
Beside the measured number, compound 3's estimate is 0.25 log units below it; measured number inside the range.
By their numbers in this assay, from the lowest: compound 3; then compounds 1 and 2 (each within the scatter of the next).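

In this assay, the position on the saturated ring carbon is not indifferent to every change: where moving the chloro left the number flat, 4-nitrophenyl in place of 3-chlorophenyl gives a number 0.72 log units lower from compound 2 to compound 3 (beyond the scatter). Nitro in place of chloro on an aromatic carbon, the one-place comparison with the 4-chlorophenyl compound, gives a number 0.72 log units lower from compound 1 to compound 3 (beyond the scatter), a step of the same size. Nothing available explains this drop. Open, as far as these compounds go, is whether an amine or a carboxylic acid in place of the chloro would lie near compound 3 or further down.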